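Chloro to benzyloxycarbonyl on the shared core

This account rests on a few compounds, and the source may have more. Where it says the series, first, only, none or still open, it means among the compounds named here.

- Compound 1 `Fc1ccc(-c2nn(-c3ccccc3)cc2-c2nc3cc(Cl)ccc3[nH]2)cc1` gives 2230 nM in a functional assay on MCF7 cells (Homo sapiens) for antiproliferative activity, read by MTT assay, with a stated time of 48 h; on this read-out higher numbers stand for weaker inhibition and lower numbers for stronger inhibition
- Compound 2 `Fc1ccc(-c2nn(-c3ccccc3)cc2-c2nc3cc(Cl)c(Cl)cc3[nH]2)cc1` gives 6930 nM in this assay

Of the two measured compounds, compound 1 stands lowest in this assay and so shows the stronger inhibition. Compound 3 `O=C(OCc1ccccc1)c1ccc2[nH]c(-c3cn(-c4ccccc4)nc3-c3ccc(F)cc3)nc2c1` is not yet measured and differs from compound 1 by benzyloxycarbonyl in place of chloro on an aromatic carbon. Within the data shown here, the only measured step, a 3.1-fold higher number from compound 1 to compound 2 (0.49 log units; beyond the scatter), places chloro on an aromatic carbon in place of hydrogen. Among the measured compounds shown here, it bears on this change only loosely, and no measured compound carries benzyloxycarbonyl. A modest rise in this assay is expected, with wide uncertainty. The expected step is a 2.2-fold higher number from compound 1 to compound 3 (0.35 log units; beyond the scatter) in size. For compound 3 the estimate is 5000 nM within a range from 1300 nM to 18000 nM in this assay as expected here.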

Compound 3, half-maximal inhibitory concentration: 9240 nM
Beside the measured number, compound 3's estimate is 1.8-fold (0.27 log units) below it; low and high end bracket the measured number.
By their numbers in this assay, from the lowest: compound 1; then compounds 2 and 3 (each within the scatter of the next).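

Putting benzyloxycarbonyl in place of chloro on the carbon that carries chloro in compound 1 gives a 4.1-fold higher number from compound 1 to compound 3 (0.62 log units; beyond the scatter) in this assay. This is the first change shown at this position itself, and it shows that the larger group, with its added aromatic ring, comes with weaker inhibition than chloro. No measured evidence on the compounds explains this step.

The compounds shown do not separate the carbonyl from the benzyl part of the group. As far as these compounds go, a carboxylic acid, a methyl ester or an amide at this position would address that, and the effect of an amine here also remains open.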